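Sulfonyl aryl replacement in the shared core series

The source may hold more compounds than are shown below. What is called first, only, known or untested is meant among the compounds shown, and "the series" means these compounds.

Compound 3 `CNC(=O)c1cccc(S(=O)(=O)c2ccccc2Cc2c3c(n(CC(=O)O)c2C)CCNC3=O)c1` carries a 3-(methylcarbamoyl)phenyl on the sulfonyl sulfur and in a functional assay on CHO.K1 cells for antagonist activity at prostaglandin D2 receptor 2 (Homo sapiens), read by GTPgammaS binding, with a stated time of 1 h (on this read-out higher numbers stand for weaker inhibition and lower numbers for stronger inhibition), gives 240 nM, the highest number of the three measured compounds. Its nearest neighbour is compound 2 `COc1cccc(S(=O)(=O)c2ccccc2Cc2c3c(n(CC(=O)O)c2C)CCNC3=O)c1`, which in this assay gives 12 nM; compound 1 `Cc1c(Cc2ccccc2S(=O)(=O)c2cccc(Cl)c2)c2c(n1CC(=O)O)CCNC2=O` gives 4 nM in this assay. The measured steps run a 3.0-fold higher number from compound 1 to compound 2 (0.48 log units; beyond the scatter), a 60-fold higher number from compound 1 to compound 3 (1.78 log units; beyond the scatter) and a 20-fold higher number from compound 2 to compound 3 (1.30 log units; beyond the scatter).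

Compound 4 `Cc1c(Cc2ccccc2S(=O)(=O)c2ccc(F)cc2)c2c(n1CC(=O)O)CCNC2=O` is reached from compound 3 by 4-fluorophenyl in place of 3-(methylcarbamoyl)phenyl on a sulfonyl sulfur. Going by the values given here, the steps that bear on this are the two that brought the methylcarbamoyl in, a 60-fold higher number from compound 1 to compound 3 (1.78 log units; beyond the scatter) and a 20-fold higher number from compound 2 to compound 3 (1.30 log units; beyond the scatter), both large; compound 4 takes that group out again and replaces it with a fluorine, while compound 1 shows that a chloro on the sulfonyl aryl sits at 4 nM. Among the compounds with values here, no measured pair shows a 4-fluorophenyl on the sulfonyl sulfur, so the exact landing point is open. A large drop is therefore expected for compound 4, a step of a 24-fold lower number from compound 3 to compound 4 (1.38 log units; beyond the scatter) in this assay, back toward the numbers of compounds 1 and 2. The estimate for compound 4 is 10 nM, with a range from 3 nM to 40 nM.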

Compound 4, half-maximal inhibitory concentration: 3.3 nM
Beside the measured number, compound 4's estimate is 3.0-fold (0.48 log units) above it, and the stated range covers the measured number.
By their numbers in this assay, from the lowest: compounds 4 and 1 (each within the scatter of the next); then compound 2; then compound 3.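

On a sulfonyl sulfur, 4-fluorophenyl in place of 3-(methylcarbamoyl)phenyl gives a 73-fold lower number from compound 3 to compound 4 (1.86 log units; beyond the scatter), so the high number of compound 3 is not set by the shared core alone. In this assay, 4-fluorophenyl and 3-chlorophenyl cannot be told apart, with a 1.2-fold lower number from compound 1 to compound 4 (0.08 log units; within the scatter), while 3-methoxyphenyl stands modestly apart from 4-fluorophenyl, with a 3.6-fold lower number from compound 2 to compound 4 (0.56 log units; beyond the scatter). Nothing at hand gives a reason for these differences.

The halogen and its place on the aryl ring change together between compound 1 and compound 4, so their separate contributions stay unresolved. On these data alone, it also remains open how the sulfonyl aryl would read with an amine or a carboxylic acid as its substituent, and whether other amides would share the high number of compound 3.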